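A few compounds are considered here, and "the series" means these few. Any claim that something is new, unique, unknown or untested is made for them only; others in the source may bear on it.

Compound 3, with the structure `Cc1cc(S(=O)(=O)/N=C(\N)n2nccc2-c2ccccc2)c(SCc2ccc(C(F)(F)F)cc2)cc1Cl`, stands second highest of the three numbers in a functional assay on HCT-116 cells (Homo sapiens) for cytotoxicity, read by MTT assay, with a stated time of 72 h (on this read-out lower numbers stand for stronger inhibition and higher numbers for weaker inhibition), where compound 3 gives 14000 nM. The other two values, compound 1 `Cc1cc(-c2ccccc2)n(/C(N)=N/S(=O)(=O)c2cc(C)c(Cl)cc2SCc2cccc(C(F)(F)F)c2)n1` with 19000 nM and compound 2 `Cc1cc(-c2ccccc2)n(/C(N)=N/S(=O)(=O)c2cc(C)c(Cl)cc2SCc2ccc(C(F)(F)F)cc2)n1` with 7000 nM, both lie within the scatter of compound 3. Compound 4, with the structure `Cc1cc(S(=O)(=O)/N=C(\N)n2nccc2-c2ccccc2)c(SCc2ccccc2C)cc1Cl`, carries the change (2-methylphenyl in place of 4-(trifluoromethyl)phenyl on a saturated chain carbon bound to a sulfur). Among the measured compounds shown here, two measured steps bear on it: a 2.7-fold lower number from compound 1 to compound 2 (0.43 log units; beyond the scatter), at the same place, a saturated chain carbon bound to a sulfur, and a 2.0-fold higher number from compound 2 to compound 3 (0.30 log units; within the scatter). Neither step removes a trifluoromethyl or adds a methyl, so the change is only partly covered. A modest rise is expected, estimated as a 1.4-fold higher number from compound 3 to compound 4 (0.15 log units; within the scatter). Compound 4 is therefore expected to give 20000 nM, within the range 6000 nM to 60000 nM.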

Compound 4, half-maximal inhibitory concentration: 16000 nM
For compound 4 the middle estimate is 1.3-fold (0.10 log units) above the measured one; the range from low to high includes it.
By their numbers in this assay, from the lowest: compounds 2, 3, 4 and 1 (each within the scatter of the next, the first and the last beyond it).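

In this assay, there is a 1.1-fold higher number from compound 3 to compound 4 (0.06 log units; within the scatter) when 2-methylphenyl replaces 4-(trifluoromethyl)phenyl on the saturated chain carbon bound to a sulfur. The earlier step at this place only compared 3-(trifluoromethyl)phenyl with 4-(trifluoromethyl)phenyl, whereas this pair shows that a group without trifluoromethyl gives a number within the scatter of compound 3. Nothing measured here explains this result. Still open, from the compounds shown here alone, is whether an amine or a carboxylic acid in place of the methyl of 2-methylphenyl, or a longer chain on the sulfur, would shift the number beyond the scatter.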